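The source may hold more compounds than are shown below. What is called first, only, known or untested is meant among the compounds shown, and "the series" means these compounds.

Working notes on the series. In a functional assay for inhibition, with Rattus norvegicus as the target (on this read-out lower numbers stand for stronger inhibition and higher numbers for weaker inhibition), compound 2 `CCCCc1cc(OC)c2ccccc2c1OC(C)=O` gives 440 nM, compound 1 `CCCCc1c(CCCC)c(OC(C)=O)c2ccccc2c1OC` gives 6020 nM, and compound 3 `CCc1c(CC)c(OC(C)=O)c2ccccc2c1OC` gives 400 nM. The numbers of compound 3 and compound 2 lie within the scatter of each other. The step of a 14-fold higher number from compound 2 to compound 1 (1.14 log units; beyond the scatter) arises from the change (butyl in place of hydrogen on an aromatic carbon). The cores of compound 3 and compound 2 hold the same atoms joined differently; the difference between the two cores is not broken down here. Compound 4 `CCCCc1cccc2c(OC)c(CC)c(CC)c(OC(C)=O)c12` has not been measured in this assay. It differs from compound 3 by butyl in place of hydrogen on an aromatic carbon, the same kind of change as from compound 2 to compound 1, though the place is not the same: in compound 4 the butyl enters ortho to a fused ring and meta to a fused ring, whereas in compound 1 it enters ortho to a butyl group, ortho to a methoxy group, meta to a fused ring, meta to an acetoxy group and para to a fused ring. Among the measured compounds shown here, only one measured example of this kind of change exists. Compound 4 is expected to show a step of a 6.3-fold higher number from compound 3 to compound 4 (0.80 log units; beyond the scatter) in this assay, resting on the measured step of a 14-fold higher number from compound 2 to compound 1 (1.14 log units; beyond the scatter) but tempered as the place differs. Compound 4 is accordingly estimated at 2500 nM, within a range from 600 nM to 12000 nM.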

Compound 4, half-maximal inhibitory concentration: 14100 nM
The estimate for compound 4 lay 5.6-fold (0.75 log units) below the measured number; measured number above the stated range.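

In this assay, butyl in place of hydrogen on an aromatic carbon again gives a rise, with a 35-fold higher number from compound 3 to compound 4 (1.55 log units; beyond the scatter), so the number moves the same way on both cores. Set beside the earlier step, the two sizes do not separate: the same change on two cores in this assay, a 14-fold higher number (1.14 log units; beyond the scatter) from compound 2 to compound 1 and a 35-fold higher number (1.55 log units; beyond the scatter) from compound 3 to compound 4, 2.6-fold (0.41 log units) apart, within the scatter of two such steps. In these two pairs the change therefore carries from one core to the other in direction and, within the scatter, in size, even though the butyl enters at a different place in each; two pairs do not make a rule for other cores or other places, and they do not show why the number rises.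

Still open, from the compounds shown here alone, is whether a group other than butyl on the same aromatic carbon, such as methyl or a longer chain like hexyl, gives a step of this size. Also open, going by these compounds, is how an amine or a carboxylic acid at that place would read in this assay.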